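A few compounds are considered here, and "the series" means these few. Any claim that something is new, unique, unknown or untested is made for them only; others in the source may bear on it.

In a functional assay on CHO cells with sphingosine 1-phosphate receptor 2 (Homo sapiens) as the target, read by GTPgammaS binding (on this read-out higher numbers stand for an effect only at larger amounts of compound and lower numbers for an effect already at smaller amounts), compound 2, `Cc1cc(CCC(=O)O)ccc1-c1noc(-c2ccc(OC(C)C)c(F)c2)n1`, reaches only > 10000 nM, which is a limit of the assay rather than a number. Compound 1, `Cc1cc(C(=O)O)ccc1-c1noc(-c2ccc(C3CCCCC3)cc2)n1`, gives > 10000 nM in this assay, again a limit and not a measured value. Compound 2 therefore stands at the limit of > 10000 nM in this assay, at which 2 of the 2 values shown sit, and no measured number in this set can place it higher or lower than any other compound. Compound 3, `Cc1cc(-c2nc(-c3ccc(CCC(=O)O)cc3C)no2)ccc1OC(C)C`, differs from compound 2 by methyl in place of fluoro on an aromatic carbon. Going by the values given here, no step between two measured compounds is available, and compound 2 itself offers no number from which a change could be counted. The expectation for compound 3 in this assay is therefore that the step that the limit leaves unreadable from compound 2 to compound 3 stays within the scatter, with the reading most likely remaining a limit. The estimate for compound 3 is 20000 nM, expected to fall between 5000 nM and 100000 nM.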

Compound 3, half-maximal effective concentration: > 10000 nM
Compound 3: a limit, no number; the forecaster's own chance of this, stated with the estimate: 85%; the middle value is on the limit's open side.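

Going by these compounds alone, compound 2 and compound 3 are both read only as limits in this assay, so no step from the one to the other can be read. The compounds shown leave open where any of them would fall on a measured scale: the limit of > 10000 nM in this assay, at which 3 of the 3 values shown sit.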